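This account rests on a few compounds, and the source may have more. Where it says the series, first, only, none or still open, it means among the compounds named here.

Working notes on the series. Compound 1 `Cc1nc(-c2ccc(C(F)(F)F)cc2)sc1CNc1ccc(C(=O)O)cc1` carries a carboxy on an aromatic carbon of its core. For the measured compounds named here, in a functional assay on CHO cells for agonist activity at Free fatty acid receptor 1 (Homo sapiens), read by a luciferase reporter (on this read-out higher numbers stand for larger maximal responses and lower numbers for smaller maximal responses), compound 1 gives 10%, the lowest of the three numbers measured so far. Compound 2 `O=C(O)CCCc1ccc(NCc2cccc(Oc3ccccc3)c2)cc1` gives 59% and compound 3 `CC(CC(=O)O)c1ccc(NCc2cccc(Oc3ccccc3)c2)cc1` gives 83%; both gaps to compound 1 lie beyond the scatter, and compound 3 stands furthest from it.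

Compound 4 `Cc1nc(-c2ccc(C(F)(F)F)cc2)sc1CNc1ccc(C(C)CC(=O)O)cc1` differs from compound 1 in one place: 1-(carboxymethyl)ethyl in place of carboxy on an aromatic carbon; the place is an aromatic carbon of a six-membered aromatic ring of carbon only, para to a large group. Going by the values given here, the only measured step that bears on this change is a number 24 percentage points higher from compound 2 to compound 3 (beyond the scatter), where the same 1-(carboxymethyl)ethyl entered in place of 3-carboxypropyl on a different core. That step does not start from a carboxy, so it addresses the chain only indirectly, and the cores of compound 1 and compound 2 are not the same. Still, the branched acid on compound 3 gave the highest maximal response of the set, so a rise is expected for compound 4. The uncertainty is wide because compound 1 starts from 10%, which is so low.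

The expected step is a number 30 percentage points higher from compound 1 to compound 4 (beyond the scatter). For compound 4 the estimate in this assay is 40%, in a range from 15% to 75%.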

Compound 4, largest response reached (reported as percent of maximum), in percent of the reference or control that the assay uses: 109%
Compound 4: middle estimate off by 69 percentage points, on the low side, outside the stated range (above it).
By their numbers in this assay, from the lowest: compound 1; then compound 2; then compound 3; then compound 4.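

On the core of compound 1, in this assay, 1-(carboxymethyl)ethyl in place of carboxy on an aromatic carbon para to a large group gives a number 99 percentage points higher from compound 1 to compound 4 (beyond the scatter), so a low maximal response is not fixed by that core and this position can carry the change to a large effect. The earlier compounds showed this group only as a replacement for 3-carboxypropyl on another core, with a number 24 percentage points higher from compound 2 to compound 3 (beyond the scatter); the new step starts from carboxy itself and is large rather than modest, and in both listed steps the entry of 1-(carboxymethyl)ethyl raises the number, with no listed step going against it. Nothing at hand gives a measured reason for the size of the new step.

Still open, as far as these compounds go, is how much of the step belongs to the longer chain and how much to its methyl branch: 3-carboxypropyl or carboxymethyl at this place on the core of compound 1 would separate the two. Also open, from the compounds shown here alone, is whether an amide in place of the carboxylic acid at the end of the chain would keep the response.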